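Ethyl to methyl on the aryl group of compound 3

The source may hold more compounds than are shown below. What is called first, only, known or untested is meant among the compounds shown, and "the series" means these compounds.

Working notes. In an assay on IM-9 cells for displacement of a labelled ligand from Substance-P receptor (Homo sapiens), read by scintillation counting, with a stated time of 30 min (a lower number here means a stronger inhibitor, a higher number a weaker inhibitor), compound 1 `CC(=O)N1CC[C@H](C(=O)N(C)Cc2cc(C(F)(F)F)cc(C(F)(F)F)c2)[C@H](c2ccccc2)C1` gives 3.2 nM, and compound 2 `CC(=O)NCC(=O)N1CC[C@@H](C(=O)N(C)Cc2cc(C(F)(F)F)cc(C(F)(F)F)c2)[C@H](c2ccccc2)C1` gives 12 nM. Compound 3 `CCc1ccccc1[C@H]1CN(C(=O)C2CCN(C(C)=O)CC2)CC[C@@H]1C(=O)N(C)Cc1cc(C(F)(F)F)cc(C(F)(F)F)c1` gives 0.064 nM in this assay; it stands lowest of the three numbers, its gap to compound 1 and its larger gap to compound 2 both beyond the scatter, so compound 3 is the strongest inhibitor of the three measured here. Compound 4 `CC(=O)N1CCC(C(=O)N2CC[C@H](C(=O)N(C)Cc3cc(C(F)(F)F)cc(C(F)(F)F)c3)[C@@H](c3ccccc3C)C2)CC1` is the next compound; it differs from compound 3 only in hydrogen in place of methyl on a saturated chain carbon bound to an aromatic carbon, read one bond further out as 2-ethylphenyl to 2-methylphenyl. For the measured compounds named here, no measured pair shows this change. Compound 1 and compound 2 carry an unsubstituted phenyl and other acyl groups, so they give no direct reading of the ethyl-to-methyl change. The change removes one carbon only, so a small step toward a higher number is expected from compound 3 to compound 4, a 2.3-fold higher number from compound 3 to compound 4 (0.37 log units; beyond the scatter), possibly within the scatter. Compound 4 is expected at 0.15 nM, within 0.04 nM to 0.6 nM.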

Compound 4, half-maximal inhibitory concentration: 0.032 nM
Estimate against measurement, compound 4: 4.7-fold (0.67 log units) above; the measured number lies below the stated range.
By their numbers in this assay, from the lowest: compounds 4 and 3 (each within the scatter of the next); then compound 1; then compound 2.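

In this assay, for the compounds shown here, shortening 2-ethylphenyl to 2-methylphenyl gives a 2.0-fold lower number from compound 3 to compound 4 (0.30 log units; within the scatter) and is the first single-place comparison. The two compounds therefore cannot be told apart, and this position tolerates the loss of one carbon from the ethyl group with no resolved change in the number. Nothing available accounts for this result.

A longer chain such as propyl, or a methoxy group or a chlorine atom in place of the ethyl group, remains untested among the compounds shown, so the limits of this position are open. Compound 1 and compound 2 carry an unsubstituted phenyl but also differ from compound 3 in their acyl groups, so the effect of removing the alkyl group altogether cannot be read.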